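Benzyl in place of tert-butyl: an expected step

The source may report more compounds than this note shows. Statements on the series, on what has been measured and on what is new or still open speak of the compounds shown alone.

In a toxicity assay on KB cells (Homo sapiens) for cytotoxicity, read by fluorescence, with a stated time of 3 days (on this read-out lower numbers stand for an effect already at smaller amounts and higher numbers for an effect only at larger amounts of compound), compound 1 (`CCCCOC(=O)CNC(=O)[C@H](CSc1ccc([N+](=O)[O-])cc1[N+](=O)[O-])NC(=O)CC[C@H](NC(=O)CCC(C)C)C(=O)OCCCC`) gives 84 uM, and compound 2 (`CCCCOC(=O)CNC(=O)[C@H](CSc1ccc([N+](=O)[O-])cc1[N+](=O)[O-])NC(=O)CC[C@H](NC(=O)CC(C)(C)C)C(=O)OCCCC`) gives 250 uM, the higher of the two numbers. Compound 3 (`CCCCOC(=O)CNC(=O)[C@H](CSc1ccc([N+](=O)[O-])cc1[N+](=O)[O-])NC(=O)CC[C@H](NC(=O)CCc1ccccc1)C(=O)OCCCC`) carries benzyl in place of tert-butyl on a saturated chain carbon bound to a carbonyl carbon. Among the compounds with values here, the one measured step bearing on this is a 3.0-fold higher number from compound 1 to compound 2 (0.47 log units; beyond the scatter), a modest change in the same place. Within the data shown here, no compound with an aromatic ring there has been measured, so a similarly modest move toward lower numbers in this assay is expected, estimated as a 2.5-fold lower number from compound 2 to compound 3 (0.40 log units; beyond the scatter). For compound 3 the estimated value is 100 uM, with an expected range of 35 uM to 290 uM.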

Compound 3, concentration for half-maximal effect: > 300 uM
Compound 3: no number, only a limit; the forecaster's own chance of this, stated with the estimate: 15%; middle value at least 3.0-fold (0.47 log units) from the limit.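

In this assay compound 3 gives > 300 uM, which is a limit and not a number. An aromatic ring at this place therefore brings no lower number: the step from the tert-butyl compound is an at least 1.2-fold higher number from compound 2 to compound 3 (0.07 log units; that floor lies within the scatter), and the step from the isobutyl compound is an at least 3.5-fold higher number from compound 1 to compound 3 (0.55 log units; beyond the scatter). Among these three, compound 1 keeps the lowest number, and neither replacement improves on it.

Going by these compounds, how far past the limit compound 3 lies remains open. So does whether an amine or a carboxylic acid at this place would lower the number.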